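Methoxy to Nitro: Forecasting a Single Exchange

This account rests on a few compounds, and the source may have more. Where it says the series, first, only, none or still open, it means among the compounds named here.

Two compounds carry the measured numbers. Compound 1 `COc1ccc(Cl)cc1C(=O)Nc1ccc(C2=NN(c3ccccc3)C(c3ccc([N+](=O)[O-])cc3)C2)cc1` in a functional assay on the whole organism (plasma, strain albino) for inhibition, with Rattus norvegicus as the target, with stated times of 1 h and 4 h, at a dose of 25 mg/kg by the oral route (on this read-out lower numbers stand for a weaker effect and higher numbers for a stronger effect at the one dose given), gives 75.3%. Compound 2 `COc1ccc(C2CC(c3ccc(NC(=O)c4cc(Cl)ccc4OC)cc3)=NN2)cc1` in this assay gives 70.6%, the lower of the two numbers, with compound 1 standing nearest by a gap that lies within the usual scatter; the two cannot be set in order on this evidence. Compound 3 `COc1ccc(Cl)cc1C(=O)Nc1ccc(C2=NNC(c3ccc([N+](=O)[O-])cc3)C2)cc1` has not been measured. It differs from compound 2 in one place: nitro in place of methoxy on an aromatic carbon. Among the compounds with values here, no measured pair shows this same exchange on an otherwise unchanged partner; the effect must be judged from the spread seen so far. Compound 1, which also carries a nitro group, sits within the scatter of compound 2, though it differs from it in more than one place. The expected step of a number 1.4 percentage points higher from compound 2 to compound 3 (within the scatter) is estimated to be small, in no firm direction, and within the scatter. Compound 3 is expected to give about 72% in this assay, with a range from 58% to 84%.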

Compound 3, a percentage reported as inhibition, in the whole organism at one dose (the size of the read-out at that dose, not a potency): 76.3%
Estimate against measurement, compound 3: 4.3 percentage points below, within the range that was stated.
By their numbers in this assay, from the lowest: compounds 2, 1 and 3 (each within the scatter of the next).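

Within the data shown here, with compound 3 the exchange of 4-methoxyphenyl to 4-nitrophenyl can be read for the first time on an otherwise unchanged partner: in this assay it gives a number 5.7 percentage points higher from compound 2 to compound 3 (within the scatter), so at this place, para to a large group, the read-out at the one dose does not separate the two groups. Compound 3 also completes a second single change, hydrogen in place of phenyl on an amine nitrogen in a ring, and this gives a number 1 percentage points higher from compound 1 to compound 3 (within the scatter), so with the nitro group present, this change likewise produces no step beyond the scatter. Nothing in the data presented speaks to what lies behind either step.

The compounds shown leave open whether a different group at this place, such as an amine or a carboxylic acid, would give a step beyond the scatter, since only methoxy and nitro have been compared there. They also leave open whether the three compounds would separate at other doses, as a reading at a single dose gives the size of the effect and not a potency.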